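Series notes: bromo in place of isopropyl, compound 3

The source may report more compounds than this note shows. Statements on the series, on what has been measured and on what is new or still open speak of the compounds shown alone.

Measured so far:
compound 1 `Cc1ccc(-c2nc(CNc3ccc(C(=O)NO)cc3)n(-c3ccccc3)n2)o1` — 60.7%
compound 2 `CC(C)c1ccc(-n2nc(-c3ccccc3)nc2CNc2ccc(C(=O)NO)cc2)cc1` — 52.6%

In an assay on Sf9 cells for inhibition of protein deacetylase HDAC6 (Homo sapiens), read by fluorescence, with a stated time of 40 min, tested at 100 nM (on this read-out lower numbers stand for less inhibition and higher numbers for more inhibition at the one concentration tested (going by the name of the read-out)), compound 2 gives 52.6%, and compound 1 gives 60.7%; the two numbers sit within the usual scatter of each other, so compound 2 cannot be set apart from compound 1 on these data.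

Compound 3 `O=C(NO)c1ccc(NCc2nc(-c3ccccc3)nn2-c2ccc(Br)cc2)cc1` differs from compound 2 by bromo in place of isopropyl on an aromatic carbon. Among the measured compounds shown here, no measured pair carries this change, so nothing measured guides the direction. The step of a number 2.4 percentage points higher from compound 2 to compound 3 (within the scatter) is expected to stay within the scatter, neither way. Compound 3 is estimated at 55%, with a range of 35% to 75%.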

Compound 3, a percentage reported as inhibition, at one concentration (the size of the read-out at that concentration, not a potency): 65.9%
For compound 3 the middle estimate is 10.9 percentage points below the measured one; low and high end bracket the measured number.
By their numbers in this assay, from the lowest: compounds 2, 1 and 3 (each within the scatter of the next, the first and the last beyond it).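

In this assay, among the compounds shown here, bromo in place of isopropyl on an aromatic carbon gives a number 13.3 percentage points higher from compound 2 to compound 3 (beyond the scatter) as a modest step, the only single-place step so far. The read-out therefore depends on the group at this place, para to a large group on the six-membered aromatic ring, and 4-bromophenyl reads above 4-isopropylphenyl. Nothing at hand accounts for this step.

Still open, going by these compounds, is how other groups at this place would read, such as an amine, a carboxylic acid or a longer chain. On these data alone, whether the same change gives a similar step on another core also remains open.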